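The source may report more compounds than this note shows. Statements on the series, on what has been measured and on what is new or still open speak of the compounds shown alone.

Measured so far in a functional assay on MCF7 cells (Homo sapiens) for positive allosteric modulation, read by sulforhodamine B assay, with a stated time of 48 h; on this read-out lower numbers stand for stronger inhibition of growth and higher numbers for weaker inhibition of growth:
- compound 1 `Cc1nn(-c2ccccc2)c(Oc2ccc(-c3nc4cc(C(=O)NCc5ccccc5)ccc4[nH]3)cc2)c1[N+](=O)[O-]`: 40 nM
- compound 2 `Cc1nn(-c2ccccc2)c(Oc2ccc(-c3nc4cc([N+](=O)[O-])ccc4[nH]3)cc2)c1[N+](=O)[O-]`: > 100000 nM (a limit of the assay, not a number)
- compound 3 `Cc1nn(-c2ccccc2)c(Oc2ccc(-c3nc4cc(C(=O)NC(C)C)ccc4[nH]3)cc2)c1[N+](=O)[O-]`: 99 nM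

Of the two values that are true numbers, compound 3 has the higher one. The gap to its nearest neighbour is a 2.5-fold higher number from compound 1 to compound 3 (0.39 log units; beyond the scatter).

Compound 4 `Cc1nn(-c2ccccc2)c(Oc2ccc(-c3nc4cc(C(=O)O)ccc4[nH]3)cc2)c1[N+](=O)[O-]` has not yet been measured. The change from compound 3 is hydroxy in place of isopropylamino on a carbonyl carbon. Put simply, this is hydroxy in place of isopropylamino on a carbonyl carbon, so isopropylcarbamoyl becomes carboxy.

Among the compounds with values here, two measured steps bear on this place in the molecule. Exchanging the group on the amide nitrogen gave only the modest step already shown, while keeping the carbamoyl group in both compounds. Removing the carbamoyl group altogether mattered far more, as the large at least 2500-fold higher number from compound 1 to compound 2 (3.39 log units; beyond the scatter) shows, and so does an at least 1000-fold lower number from compound 2 to compound 3 (3.00 log units; beyond the scatter). Compound 4 falls between these cases: it keeps the carbonyl but loses the amide nitrogen. Within the data shown here, no measured compound carries carboxy, so the uncertainty is wide. In this assay, a clear move towards a higher number is therefore expected, larger than the step between the two amides but smaller than the steps involving nitro.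

The estimated step is a 15-fold higher number from compound 3 to compound 4 (1.18 log units; beyond the scatter). For compound 4 the expected value is 1500 nM, with an estimated range from 100 nM to 30000 nM.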

Compound 4, concentration for 50% growth inhibition: 68 nM
Estimate against measurement, compound 4: 22-fold (1.34 log units) above; measured number outside the range, below it.
By their numbers in this assay, from the lowest: compounds 1, 4 and 3 (each within the scatter of the next, the first and the last beyond it). At a limit, above all of these: compound 2.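

In this assay, the amide nitrogen and the isopropyl group on it prove unnecessary at this carbonyl carbon: a 1.5-fold lower number from compound 3 to compound 4 (0.16 log units; within the scatter), and a 1.7-fold higher number from compound 1 to compound 4 (0.23 log units; within the scatter), so the carboxylic acid cannot be told apart from either amide, and the earlier idea that this change must cost much activity does not hold. Compound 2, which carries nitro on this aromatic carbon, has a value that is a limit of the assay and not a number: the limit of > 100000 nM in this assay, at which 1 of the 4 values shown sits. Putting carboxy in place of that nitro gives an at least 1400-fold lower number from compound 2 to compound 4 (3.16 log units; beyond the scatter), so among the four compounds, the three with a carbonyl here are all far from compound 2, the only one without it.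

Going by these compounds, whether the carbonyl itself is what matters remains open, as a methyl ester, an unsubstituted carbamoyl group or an aminomethyl group at this place would each test that in a different way. Four compounds also cannot show whether a longer chain on the amide nitrogen would separate from compound 1 and compound 4 in this assay.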